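This account rests on a few compounds, and the source may have more. Where it says the series, first, only, none or still open, it means among the compounds named here.

Within the data shown here, in an ADME assay on L02 cells (Homo sapiens) for antiproliferative activity, read by MTT assay, with a stated time of 48 h (a higher number here means a weaker inhibitor, a lower number a stronger inhibitor), compound 1 `CCOC(=O)CN(C)C(=O)c1ccc(C(CC)(CC)c2ccc(OCCC(O)(CC)CC)c(C)c2)n1CC` gives 1990 nM and compound 2 `CCn1c(C(=O)N(C)CC(=O)O)ccc1C(CC)(CC)c1ccc(OCCC(O)(CC)CC)c(C)c1` gives 2150 nM, so compound 2 sits level with the only other measured compound. Compound 3 `CCC(C)C(CO)NC(=O)c1ccc(C(CC)(CC)c2ccc(OCCC(O)(CC)CC)c(C)c2)n1CC` differs from compound 2 as follows: (1-(hydroxymethyl)-2-methylbutyl)amino in place of (carboxymethyl)(methyl)amino on a carbonyl carbon. In words, (1-(hydroxymethyl)-2-methylbutyl)amino stands in place of (carboxymethyl)(methyl)amino on a carbonyl carbon. Among the measured compounds shown here, only one measured step bears on this, a 1.1-fold higher number from compound 1 to compound 2 (0.03 log units; within the scatter), where hydrogen replaces ethyl within the same substituent. Going by these compounds, a shift beyond the scatter is therefore not expected in either direction, although a swap of this kind remains untested. The expected step is a 1.1-fold lower number from compound 2 to compound 3 (0.03 log units; within the scatter). Compound 3 is estimated at 2000 nM, with an expected range of 650 nM to 6000 nM.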

Compound 3, half-maximal inhibitory concentration: > 50000 nM
Compound 3 ended at the assay's limit; the forecaster's own chance of this, stated with the estimate: 10%; at least 25-fold (1.39 log units) between middle value and limit.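

Hydrogen in place of ethyl had changed nothing beyond the scatter in this assay, but the group on this carbonyl carbon proves far from indifferent: the new swap gives an at least 23-fold higher number from compound 2 to compound 3 (1.36 log units; beyond the scatter), and an at least 25-fold higher number from compound 1 to compound 3 (1.40 log units; beyond the scatter). The value of compound 3, > 50000 nM, is a limit of the assay, not a number.

The swap replaces the whole group at once, so the branched chain, its hydroxyl and the lost methyl on the nitrogen remain unseparated. Going by these compounds, whether a plain methylamino or a 2-hydroxyethylamino group on this carbon would behave like compound 2 or compound 3 stays open.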